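The source may hold more compounds than are shown below. What is called first, only, known or untested is meant among the compounds shown, and "the series" means these compounds.

Compound 1, `CCN1CCc2c(sc(NC(=O)NCC3CCCO3)c2C(N)=O)C1`: in a functional assay (strain AB) with Danio rerio as the target, read by microscopy, with a stated time of 1 h (a lower number here means that less compound is needed, a higher number that more compound is needed for the effect), compound 1 gives > 25000 nM, which is a limit of the assay rather than a number.
Compound 2, `CCN1CCc2c(sc(NC(=O)Nc3ccccc3)c2C(N)=O)C1`: in this assay compound 2 gives > 25000 nM, again a limit of the assay.
Compound 3, `CCN1CCc2c(sc(NC(=O)Nc3cccc(Cl)c3Cl)c2C(N)=O)C1`: in this assay compound 3 gives 17400 nM.

Among the measured compounds shown here, compound 3 thus holds the only number in this set; the other two values stand at the limit of > 25000 nM in this assay, at which 2 of the 3 values shown sit. The step from compound 1 to compound 2 is a step that the two limits leave unreadable from compound 1 to compound 2. Going to compound 3 is readable in direction only: an at least 1.4-fold lower number from compound 1 to compound 3 (0.15 log units; that floor lies within the scatter), and an at least 1.4-fold lower number from compound 2 to compound 3 (0.15 log units; that floor lies within the scatter). Both steps end at compound 3, and both have floors that lie within the scatter, so they give a weak hint at best.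

Compound 4, `CCN1CCc2c(sc(NC(=O)NCc3cccc(Cl)c3)c2C(N)=O)C1`, differs from compound 3 in one place: 3-chlorobenzyl in place of 2,3-dichlorophenyl on an amide-type nitrogen. The step from compound 2 to compound 3 bears most on this change, since it put the 2,3-dichlorophenyl in; moving away from that group is expected to raise the number in this assay, possibly back to a limit. Compound 4 is therefore estimated at 30000 nM, in a range from 10000 nM to 100000 nM. The expected step is a 1.7-fold higher number from compound 3 to compound 4 (0.24 log units; within the scatter).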

Compound 4, half-maximal effective concentration: > 25000 nM
Compound 4: no number, only a limit; the forecaster's own chance of this, stated with the estimate: 55%; the middle value lies beyond the limit too.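

With 3-chlorobenzyl in place of 2,3-dichlorophenyl on the amide-type nitrogen, the heavy-atom count stays the same and one aromatic ring of carbon remains, yet the only readable new result is an at least 1.4-fold higher number from compound 3 to compound 4 (0.15 log units; that floor lies within the scatter). This is a weak hint that a chlorine-bearing aromatic ring on this nitrogen is not enough by itself to give a number in this assay. The steps to compound 4 from compound 1 and compound 2 cannot be read, and compound 3 remains the only compound with a number: the limit of > 25000 nM in this assay, at which 3 of the 4 values shown sit.

This change removes one chlorine and adds a carbon between the ring and the nitrogen, so the effects of these two differences cannot be separated. A 2,3-dichlorobenzyl group on the same nitrogen would bear directly on that question.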